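The compounds below may be only part of what the source reports. "The series", "measured", "known", "first", "only" and "open" are said of these compounds alone.

Of the compounds shown here, three have been measured in a physicochemical assay for solubility, read by nephelometry, measured as kinetic solubility, at pH 2.0; a higher number here means a more soluble compound, a lower number a less soluble compound. Compound 1 `COc1ccc(-c2cnc(NC(=O)c3ccc(F)cc3)n2C)cc1` gives 12.5 ug/mL. Compound 2 `O=C(Nc1ncc(-c2ccccc2)o1)c1ccc(F)cc1` gives 25 ug/mL. Compound 3 `Cn1c(-c2ccc(Cl)cc2)cnc1NC(=O)c1ncc[nH]1` gives 50 ug/mL, the highest of the three numbers; its nearest neighbour is compound 2, whose number is lower by an amount within the scatter, so no order between compound 3 and compound 2 can be drawn. Compound 1 stands furthest from compound 3, lower by an amount beyond the scatter.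

Compound 4 `Cn1c(-c2cccc(Cl)c2)cnc1NC(=O)c1ncc[nH]1` has not yet been measured in this assay. It differs from compound 3 in one respect: 3-chlorophenyl in place of 4-chlorophenyl on an aromatic carbon. The same atoms are present, joined differently. Among the compounds with values here, no pair of measured compounds differs in this way, so there is no measured step to lean on. The step is expected to be small and without a clear direction beyond the scatter: a 1.2-fold higher number from compound 3 to compound 4 (0.08 log units; within the scatter). For compound 4 the solubility in this assay is expected to come out near 60 ug/mL, within a range from 25 ug/mL to 125 ug/mL.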

Compound 4, solubility: 12.5 ug/mL
Compound 4: middle estimate off by 4.8-fold (0.68 log units), on the high side; the whole stated range lies above it.
By their numbers in this assay, from the lowest: compounds 1, 4, 2 and 3 (each within the scatter of the next, the first and the last beyond it).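

In this assay, 3-chlorophenyl in place of 4-chlorophenyl on the aromatic carbon gives a 4.0-fold lower number from compound 3 to compound 4 (0.60 log units; beyond the scatter). Within the data shown here, this is the first measured change at a single place, and it shows that this position is sensitive to where the chlorine stands on the phenyl ring, even though the atoms are the same and the counted features of the two groups match. No measurement at hand bears on the origin of this step.

From the compounds shown here alone, the finding rests on one pair, so whether the same shift of the chlorine would give a similar step with other amide groups on the shared core remains open. Also open, going by these compounds, is how this position would respond to a phenyl ring carrying an amine or a carboxylic acid in place of the chlorine.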